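Pyrimidinyl for methoxypyridinyl in a diaryl urea series

A few compounds are considered here, and "the series" means these few. Any claim that something is new, unique, unknown or untested is made for them only; others in the source may bear on it.

Compound 1 `COc1ccc(-c2ccc(OC(F)(F)F)c(NC(=O)Nc3ccncc3)c2)cn1` is measured in a functional assay on A549 cells (Homo sapiens) for inhibition, read by MTT assay, with a stated time of 48 h; on this read-out higher numbers stand for weaker inhibition and lower numbers for stronger inhibition. Compound 1 reaches only a limit there, > 300000 nM, which is a limit and not a number (the limit of > 300000 nM in this assay, at which 1 of the 3 values shown sits). Compound 2 `O=C(Nc1ccncc1)Nc1cc(-c2cncnc2)ccc1OC(F)(F)F` gives 3750 nM in this assay. The change between them is pyrimidin-5-yl in place of 6-methoxypyridin-3-yl on an aromatic carbon, and it produces an at least 80-fold lower number from compound 1 to compound 2 (1.90 log units; beyond the scatter). Compound 3 `COc1ccc(-c2cc(NC(=O)Nc3nccs3)cc(C(F)(F)F)c2)cn1` has no result in this assay, where its entry reads "not determined" (no result reported); the difference between the core of compound 3 and the core of compound 1 is not broken down here. Compound 4 `O=C(Nc1cc(-c2cncnc2)cc(C(F)(F)F)c1)Nc1nccs1` carries the same kind of change on compound 3: pyrimidin-5-yl in place of 6-methoxypyridin-3-yl on an aromatic carbon. The surroundings are not the same: in the earlier pair the place is meta to a large group and para to a trifluoromethoxy group, here it is meta to a ((1,3-thiazol-2-yl)carbamoyl)amino group and meta to a trifluoromethyl group. Given an at least 80-fold lower number from compound 1 to compound 2 (1.90 log units; beyond the scatter), a large downward step is expected here too, anchored only on compound 2 at 3750 nM. Compound 4 is expected to give about 5000 nM, between 500 nM and 60000 nM.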

Compound 4, half-maximal inhibitory concentration: 18300 nM
Compound 4: the middle estimate sits 3.7-fold (0.56 log units) below what was measured; the range from low to high includes it.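

No step can be read from compound 3 to compound 4, as compound 3 has no reported result in this assay. On these data alone, whether pyrimidin-5-yl in place of 6-methoxypyridin-3-yl lowers the number on the core of compound 3, as it does on the core of compound 1, stays open.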